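Benzyloxy for chloro: expected cytotoxicity of compound 4

This account rests on a few compounds, and the source may have more. Where it says the series, first, only, none or still open, it means among the compounds named here.

Measured so far in a toxicity assay on Vero cells (Chlorocebus sabaeus) for cytotoxicity; a lower number here means that less compound is tolerated, a higher number that more compound is tolerated:
compound 1 `O=C(/C=C/c1ccc([N+](=O)[O-])o1)c1ccc(Cl)cc1` gives 558000 nM
compound 2 `O=C(/C=C/c1ccc([N+](=O)[O-])o1)c1ccc(Cl)cc1Cl` gives 417000 nM
compound 3 `COc1cc(C(=O)/C=C/c2ccc([N+](=O)[O-])o2)cc(OC)c1OC` gives 384000 nM

Compound 1 stands among three values that cannot be told apart: the step of a 1.3-fold lower number from compound 1 to compound 2 (0.13 log units; within the scatter) is within the scatter, and compound 3 differs from compound 1 by no more than that. Nothing in the set separates one compound from another in this assay.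

Compound 4 `O=C(/C=C/c1ccc([N+](=O)[O-])o1)c1ccc(OCc2ccccc2)cc1` is not yet measured. It differs from compound 1 by benzyloxy in place of chloro on an aromatic carbon, that is, benzyloxy in place of chloro, at a place para to a large group. Going by the values given here, the only measured step that touches the same ring is the chloro-for-hydrogen change, a 1.3-fold lower number from compound 1 to compound 2 (0.13 log units; within the scatter), and it lies within the scatter. Among the compounds with values here, no measured step introduces a benzyloxy group or any group of comparable size, so there is no direct precedent for the change at hand.

On this basis compound 4 is expected to give a number close to that of compound 1, with a step of a 1.2-fold lower number from compound 1 to compound 4 (0.09 log units; within the scatter) that is not expected to exceed the scatter. The estimate for compound 4 in this assay is 450000 nM, within a range from 200000 nM to 1000000 nM.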

Compound 4, half-maximal cytotoxic concentration: 515000 nM
The estimate for compound 4 lay 1.1-fold (0.06 log units) below the measured number; low and high end bracket the measured number.
By their numbers in this assay, from the lowest: compounds 3, 2, 4 and 1 (each within the scatter of the next).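

In this assay, the step for benzyloxy in place of chloro on the aromatic carbon para to a large group is a 1.1-fold lower number from compound 1 to compound 4 (0.03 log units; within the scatter), so this exchange does not separate the two compounds. The earlier compounds shown here offered only a single-atom change on this ring, whereas this change replaces 1 heavy atom with 8 heavy atoms, bringing in a six-membered aromatic ring and a hydrogen-bond acceptor, and the reading still stays within the scatter; at this place, then, the read-out tolerates a much larger group than chloro without a distinguishable shift. No measurement bears on why the reading stays flat across this change.

The compounds shown leave open whether an amine or a carboxylic acid at this same place, each a different kind of group from chloro and benzyloxy, would also stay within the scatter of compound 1. They also leave open whether any replacement in the shared core outside this ring, such as exchanging the nitro group for a nitrile, would move the number beyond the scatter.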